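Cyclopropyl for Methyl on the Amide of Compound 3

This account rests on a few compounds, and the source may have more. Where it says the series, first, only, none or still open, it means among the compounds named here.

The measured compounds:
Compound 1, `CNc1nc(Cl)nc2c1ncn2[C@@H]1O[C@H](C(=O)NC2CC2)[C@@H](O)[C@H]1O`, gives 2.82 nM in an assay on CHO cells for displacement of a labelled ligand from adenosine receptor A3 (Homo sapiens); on this read-out lower numbers stand for stronger inhibition and higher numbers for weaker inhibition.
Compound 2, `O=C(NC1CC1)[C@H]1O[C@@H](n2cnc3c(NC4CC4)nc(Cl)nc32)[C@H](O)[C@@H]1O`, gives 5.62 nM in this assay.
Compound 3, `CNC(=O)[C@H]1O[C@@H](n2cnc3c(NCc4ccccc4C)nc(Cl)nc32)[C@H](O)[C@@H]1O`, gives 2.19 nM in this assay.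

Compound 3 shows the lowest of the three numbers. Its gap to compound 1 lies within the scatter, so the two cannot be ranked; only its gap to compound 2 lies beyond it. Compound 4, `Cc1ccccc1CNc1nc(Cl)nc2c1ncn2[C@@H]1O[C@H](C(=O)NC2CC2)[C@@H](O)[C@H]1O`, is the next compound. It differs from compound 3 in one place: cyclopropyl in place of methyl on an amide-type nitrogen.

Among the measured compounds shown here, no measured step makes this exact change. The closest is a 2.0-fold higher number from compound 1 to compound 2 (0.30 log units; within the scatter), where the same groups were swapped on a nitrogen on an aromatic ring rather than on the amide nitrogen, and that step stayed within the scatter. Compounds 1 and 3 differ in two places, so their values alone give no guide to the amide change. On this basis the step is expected to be small, a 1.1-fold higher number from compound 3 to compound 4 (0.06 log units; within the scatter), with no clear direction. Compound 4 is therefore expected to give about 2.5 nM in this assay, estimated between 1 nM and 6.3 nM.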

Compound 4, inhibition constant: 27.5 nM
Beside the measured number, compound 4's estimate is 11-fold (1.04 log units) below it; measured number above the stated range.
By their numbers in this assay, from the lowest: compounds 3, 1 and 2 (each within the scatter of the next, the first and the last beyond it); then compound 4.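

The amide-type nitrogen proves a sensitive place in this assay: cyclopropyl in place of methyl there gives a 13-fold higher number from compound 3 to compound 4 (1.10 log units; beyond the scatter). With cyclopropyl held on the amide, the group on the nitrogen on an aromatic ring counts as well: 2-methylbenzyl in place of cyclopropyl gives a 4.9-fold higher number from compound 2 to compound 4 (0.69 log units; beyond the scatter), and 2-methylphenyl in place of hydrogen on the saturated chain carbon bound to that nitrogen gives a 9.8-fold higher number from compound 1 to compound 4 (0.99 log units; beyond the scatter). The size of a swap from methyl to cyclopropyl therefore cannot be carried over from one compound pair to another: the same change on two cores in this assay, a 2.0-fold higher number (0.30 log units; within the scatter) from compound 1 to compound 2 and a 13-fold higher number (1.10 log units; beyond the scatter) from compound 3 to compound 4, 6.3-fold (0.80 log units) apart, beyond the scatter of two such steps.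

Going by these compounds, it stays open whether an ethyl or isopropyl group on the amide nitrogen would behave like methyl or like cyclopropyl. Also open, on these data alone, is whether a plain benzyl group on the nitrogen on an aromatic ring would give the same pattern as 2-methylbenzyl.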